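Amide to urea swap on the shared core

A few compounds are considered here, and "the series" means these few. Any claim that something is new, unique, unknown or untested is made for them only; others in the source may bear on it.

Within the data shown here, compound 2 `O=C(C1CCOCC1)N1CCc2nc(C#Cc3ccccc3)sc2C1` gives 290 nM in an assay on HEK293 cells for positive allosteric modulation of metabotropic glutamate receptor 5 (Homo sapiens), read by FLIPR, with a stated time of 1 h (on this read-out higher numbers stand for an effect only at larger amounts of compound and lower numbers for an effect already at smaller amounts), the only number measured so far. Compound 1 `CCN1CCc2nc(C#Cc3ccccc3)sc2C1` reaches a limit of this assay rather than a number, > 10000 nM (the limit of > 10000 nM in this assay, at which 1 of the 2 values shown sits). Among the measured compounds shown here, the single measured step, an at least 34-fold lower number from compound 1 to compound 2 (1.53 log units; beyond the scatter), changes the group on the amine nitrogen in the ring and not the carbonyl side. Compound 3 `O=C(N1CCCC1)N1CCc2nc(C#Cc3ccccc3)sc2C1` differs from compound 2 by pyrrolidin-1-yl in place of oxan-4-yl on a carbonyl carbon. For the measured compounds named here, no measured step touches this position, so no change beyond the scatter is expected in this assay. Compound 3 is estimated at 500 nM in this assay, with a range from 150 nM to 2000 nM. The expected step is a 1.7-fold higher number from compound 2 to compound 3 (0.24 log units; within the scatter).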

Compound 3, half-maximal effective concentration: 9.8 nM
The estimate for compound 3 lay 51-fold (1.71 log units) above the measured number; the whole stated range lies above it.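

Among these compounds, the group on the carbonyl carbon, which no earlier step touched, strongly shapes the read-out: this assay shows a 30-fold lower number from compound 2 to compound 3 (1.47 log units; beyond the scatter) for pyrrolidin-1-yl in place of oxan-4-yl. Replacing ethyl on the amine nitrogen in the ring with (pyrrolidin-1-yl)carbonyl gives an at least 1000-fold lower number from compound 1 to compound 3 (3.00 log units; beyond the scatter). Compound 1 stands at a limit rather than a number, so this step is only a bound: the limit of > 10000 nM in this assay, at which 1 of the 3 values shown sits.

The compounds shown do not separate the ring nitrogen on the carbonyl carbon from the five-membered ring size. A piperidin-1-yl or cyclopentyl group at this place would address that question.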